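The source may hold more compounds than are shown below. What is called first, only, known or untested is meant among the compounds shown, and "the series" means these compounds.

Compound 1 `Cn1nc(-c2nnc(-c3ccccc3Cl)o2)c2ccccc21` in an ADME assay on L02 cells (Homo sapiens) for cytotoxicity, read by MTT assay, with a stated time of 72 h (on this read-out higher numbers stand for weaker inhibition and lower numbers for stronger inhibition), gives > 100000 nM, which is a limit of the assay and not a number. Compound 2 `Cn1nc(-c2nnc(-c3cccc(Cl)c3)o2)c2ccccc21` in this assay gives > 100000 nM, again a limit. Compound 3 `Cn1nc(-c2nnc(-c3ccc(O)cc3)o2)c2ccccc21` in this assay gives > 100000 nM, also a limit. The steps a step that the two limits leave unreadable from compound 1 to compound 2, a step that the two limits leave unreadable from compound 1 to compound 3 and a step that the two limits leave unreadable from compound 2 to compound 3 therefore cannot be sized, since (the limit of > 100000 nM in this assay, at which 3 of the 3 values shown sit). Compound 2 thus stands at the limit, together with the other two values shown.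

Compound 4 `Cn1nc(-c2nnc(-c3cccc(Br)c3)o2)c2ccccc21` differs from compound 2 by bromo in place of chloro on an aromatic carbon. Going by the values given here, no measured step covers this change, and none of the three measured steps gives a readable size. Compound 4 is expected to stay at the limit as well, so a step that the limit leaves unreadable from compound 2 to compound 4 is expected to show no step beyond the scatter. For compound 4 the estimate is 200000 nM, expected between 80000 nM and 600000 nM.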

Compound 4, half-maximal inhibitory concentration: > 100000 nM
Compound 4: only a limit was reported; the forecaster's own chance of this, stated with the estimate: 85%; the middle value is on the limit's open side.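

Compound 4 gives > 100000 nM in this assay, a limit of the assay and not a number. Its steps from compound 1, compound 2 and compound 3 cannot be read: the limit of > 100000 nM in this assay, at which 4 of the 4 values shown sit.

Still open, going by these compounds, is where any of compound 1, compound 2, compound 3 and compound 4 lies beyond the limit, and so whether bromo in place of chloro changes anything.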